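The source may hold more compounds than are shown below. What is called first, only, known or untested is meant among the compounds shown, and "the series" means these compounds.

Measured compounds: compound 1 `COc1nc(C)c(Nc2nc(Cl)cn([C@H](COC(=O)c3ccccc3)C3CC3)c2=O)cc1C` with 1.5 nM in an assay on frontal cortex for displacement of a labelled ligand from corticotropin-releasing factor receptor 1 (Rattus norvegicus), with a stated time of 2 h; on this read-out higher numbers stand for weaker inhibition and lower numbers for stronger inhibition; compound 2 `CCCNC(=O)OC[C@H](C1CC1)n1cc(Cl)nc(Nc2cc(C)c(OC)nc2C)c1=O` with 10 nM in this assay.

Compound 2 stands at the highest of the two numbers; the nearest is compound 1, reached by the step of a 6.7-fold higher number from compound 1 to compound 2 (0.82 log units; beyond the scatter), a change of propylamino in place of phenyl on a carbonyl carbon.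

Compound 3 `COc1nc(C)c(Nc2nc(Cl)cn([C@H](COc3ccccn3)C3CC3)c2=O)cc1C` is not yet measured. It differs from compound 2 by pyridin-2-yl in place of propylcarbamoyl on an oxygen on a saturated carbon. Among the compounds with values here, no measured step covers this change. Within the data shown here, the only step on record, a 6.7-fold higher number from compound 1 to compound 2 (0.82 log units; beyond the scatter), concerns the same side chain and shows that the aromatic variant gave a lower number than the propylamino one; compound 3 also carries an aromatic ring there, but joined through an oxygen rather than a carbonyl, so that step bears on it only loosely.

On this basis a lower number than compound 2 is expected for compound 3, of about the size a 2.5-fold lower number from compound 2 to compound 3 (0.40 log units; beyond the scatter), though with wide uncertainty. The estimate for compound 3 in this assay is 4 nM, within 1 nM to 20 nM.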

Compound 3, half-maximal inhibitory concentration: 1.2 nM
Compound 3: middle estimate off by 3.3-fold (0.52 log units), on the high side, within the range that was stated.
By their numbers in this assay, from the lowest: compounds 3 and 1 (each within the scatter of the next); then compound 2.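

In this assay, the oxygen on a saturated carbon accepts a pyridin-2-yl group joined directly, with no carbonyl in the link, and the replacement of propylcarbamoyl gives an 8.3-fold lower number from compound 2 to compound 3 (0.92 log units; beyond the scatter). The earlier pair left open whether the low number depended on the benzoyl carbonyl, but the exchange of benzoyl for pyridin-2-yl gives a 1.3-fold lower number from compound 1 to compound 3 (0.10 log units; within the scatter), so the two compounds cannot be told apart in this assay and, among the three compounds shown, the carbonyl is not required for a low number. The pattern among these three is that the two groups bearing an aromatic ring stand level and the propylcarbamoyl group gives the highest number, with no compound going against it, but no measurement on hand accounts for these steps.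

The compounds shown leave open whether the ring nitrogen of pyridin-2-yl matters, a question that a phenyl group on the same oxygen would address. They also leave open whether an aromatic ring is needed at all at this oxygen, which a cyclohexyl group or a propyl chain joined directly to it would test.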